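Swapping 4-methylpiperazin-1-yl for cyclopentylamino on a carbonyl carbon

The source may report more compounds than this note shows. Statements on the series, on what has been measured and on what is new or still open speak of the compounds shown alone.

In a functional assay on A549 cells (Homo sapiens) for inhibition, read by sulforhodamine B assay, with a stated time of 72 h (on this read-out lower numbers stand for stronger inhibition and higher numbers for weaker inhibition), compound 3 `CN1CCN(C(=O)c2c(N)sc(-c3ccc(Cl)cc3)c2-c2ccc(Cl)cc2)CC1` gives 590 nM, the middle of three numbers: compound 2 `Nc1sc(-c2ccc(Cl)cc2)c(-c2ccc(Cl)cc2)c1C(=O)NC1CCC(O)CC1` lies lower at 250 nM, and compound 1 `CC1CCN(C(=O)c2c(N)sc(-c3ccc(Cl)cc3)c2-c2ccc(Cl)cc2)CC1` lies higher at 1750 nM. Compound 4 `Nc1sc(-c2ccc(Cl)cc2)c(-c2ccc(Cl)cc2)c1C(=O)NC1CCCC1` keeps the shared core but has cyclopentylamino in place of 4-methylpiperazin-1-yl on a carbonyl carbon. For the measured compounds named here, no measured compound carries cyclopentylamino. The nearest guide is compound 2, whose (4-hydroxycyclohexyl)amino also keeps the amide hydrogen. The relevant steps are all modest: a 2.4-fold higher number from compound 2 to compound 3 (0.37 log units; beyond the scatter), a 7.0-fold lower number from compound 1 to compound 2 (0.85 log units; beyond the scatter) and a 3.0-fold lower number from compound 1 to compound 3 (0.47 log units; beyond the scatter). A similarly modest move to a lower number is therefore expected, a 2.1-fold lower number from compound 3 to compound 4 (0.32 log units; beyond the scatter). Compound 4 is estimated at 280 nM, with an expected range of 90 nM to 850 nM.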

Compound 4, half-maximal inhibitory concentration: 6790 nM
Compound 4: middle estimate off by 24-fold (1.38 log units), on the low side; the measured number lies above the stated range.
By their numbers in this assay, from the lowest: compound 2; then compound 3; then compound 1; then compound 4.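

Keeping the amide hydrogen does not by itself give a low number: cyclopentyl in place of 4-hydroxycyclohexyl on an amide-type nitrogen gives a 27-fold higher number from compound 2 to compound 4 (1.43 log units; beyond the scatter). For the compounds shown here, this position also proves more sensitive than the earlier steps suggested, with cyclopentylamino giving a 12-fold higher number from compound 3 to compound 4 (1.06 log units; beyond the scatter) and a 3.9-fold higher number from compound 1 to compound 4 (0.59 log units; beyond the scatter), which leaves compound 4 the weakest of the four. No measurement shown accounts for these steps.

From the compounds shown here alone, that change from 4-hydroxycyclohexyl to cyclopentyl alters both the ring size and the hydroxyl, so their separate contributions remain open. A plain cyclohexylamino group would help to separate them.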